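From Methoxy to Hydroxy: A Small Step Ahead

The source may hold more compounds than are shown below. What is called first, only, known or untested is meant among the compounds shown, and "the series" means these compounds.

Of the compounds shown here, two have been measured in a functional assay on A498 cells (Homo sapiens) for inhibition, read by sulforhodamine B assay, with a stated time of 48 h; a higher number here means a weaker inhibitor, a lower number a stronger inhibitor. Compound 1 `O=C(Nc1cccc(-n2cc(-c3ccncc3)c(-c3ccc(Cl)c(O)c3)n2)c1)Nc1cccc(C(F)(F)F)c1` gives 2240 nM, while compound 2 `COc1cc(-c2nn(-c3cccc(NC(=O)Nc4ccc(Cl)c(C(F)(F)F)c4)c3)cc2-c2ccncc2)ccc1Cl` gives 840 nM, the lower of the two numbers, with compound 1 clearly above it, beyond the usual scatter. Compound 3 `O=C(Nc1cccc(-n2cc(-c3ccncc3)c(-c3ccc(Cl)c(O)c3)n2)c1)Nc1ccc(Cl)c(C(F)(F)F)c1` is not yet measured. It differs from compound 2 in one place, hydrogen in place of methyl on an oxygen on an aromatic ring. Among the measured compounds shown here, no measured pair shows this change alone, and compound 1 differs from compound 3 elsewhere as well, so its number cannot stand in for this step. A modest weakening is expected, so the step from compound 2 to compound 3 is estimated at a 1.5-fold higher number from compound 2 to compound 3 (0.19 log units; within the scatter). Compound 3 is expected to give 1300 nM, within 500 nM to 3500 nM.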

Compound 3, half-maximal inhibitory concentration: 1400 nM
Estimate against measurement, compound 3: 1.1-fold (0.03 log units) below, within the range that was stated.
By their numbers in this assay, from the lowest: compounds 2, 3 and 1 (each within the scatter of the next, the first and the last beyond it).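

Putting hydroxy in place of methoxy on the 4-chloro-3-methoxyphenyl ring gives a 1.7-fold higher number from compound 2 to compound 3 (0.22 log units; within the scatter) in this assay, so at this position the two groups cannot be told apart in this assay. With hydroxy kept, chloro in place of hydrogen on an aromatic carbon gives a 1.6-fold lower number from compound 1 to compound 3 (0.20 log units; within the scatter) and is likewise not separable from the scatter. No measurement is available that offers a reason for either step. Still open, going by these compounds, is whether ethoxy or an amine on this ring carbon would give a number clearly different from those of compound 2 and compound 3.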